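Methyl in place of bromo: compound 2 to compound 3

The source may hold more compounds than are shown below. What is called first, only, known or untested is meant among the compounds shown, and "the series" means these compounds.

The series rests on a shared core carrying one substituent on an aromatic carbon. Compound 1 `CSc1nc2ccc(Cl)cn2c(=N)c1S(=O)(=O)c1ccccc1` bears chloro at that carbon; in an assay on HeLa cells for displacement of a labelled ligand from 5-hydroxytryptamine receptor 6 (Homo sapiens) (on this read-out higher numbers stand for weaker inhibition and lower numbers for stronger inhibition), compound 1 gives 28 nM. Compound 2 `CSc1nc2ccc(Br)cn2c(=N)c1S(=O)(=O)c1ccccc1` bears bromo there, and in this assay compound 2 gives 56 nM. Within the data shown here, the only step so far, a 2.0-fold higher number from compound 1 to compound 2 (0.30 log units; within the scatter), leaves compound 2 with the higher of the two numbers, but the gap sits within the scatter, so no ranking of compound 1 against compound 2 can be read from it.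

Compound 3 `CSc1nc2ccc(C)cn2c(=N)c1S(=O)(=O)c1ccccc1` is the next member. Relative to compound 2 the change is methyl in place of bromo on an aromatic carbon. Among the measured compounds shown here, the single measured step that bears on this change is the one from compound 1 to compound 2, and it was small, a 2.0-fold higher number from compound 1 to compound 2 (0.30 log units; within the scatter); exchanging one small substituent for another at this carbon left this assay essentially unchanged. On that basis a step of comparable size is expected, a 1.4-fold lower number from compound 2 to compound 3 (0.15 log units; within the scatter), with no direction beyond the scatter claimed. Compound 3 is accordingly estimated at 40 nM, expected to fall within 14 nM to 120 nM.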

Compound 3, half-maximal inhibitory concentration: 1.3 nM
The estimate for compound 3 lay 31-fold (1.49 log units) above the measured number, and the stated range ends above it.
By their numbers in this assay, from the lowest: compound 3; then compounds 1 and 2 (each within the scatter of the next).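

In this assay, this aromatic carbon is far from indifferent to its substituent: the methyl of compound 3 gives a 43-fold lower number from compound 2 to compound 3 (1.63 log units; beyond the scatter) and a 22-fold lower number from compound 1 to compound 3 (1.33 log units; beyond the scatter), whereas exchanging one halogen for the other gave only a 2.0-fold higher number from compound 1 to compound 2 (0.30 log units; within the scatter). The change is also small on paper, since bromo and methyl each count one heavy atom, no ring and no hydrogen-bond donors or acceptors, so these counts do not separate the groups even though the numbers do. No measurement available here accounts for the separation of methyl from chloro and bromo.

With methyl as the only carbon substituent shown at this position, it remains open whether the low number of compound 3 is particular to methyl or extends to ethyl, a longer chain, methoxy or an amine. The compounds shown also differ only at this carbon, so it is unknown whether methyl would give a step of similar size on the shared core with another group, such as a pyridine ring, in place of the phenyl on the sulfone.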